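The compounds below may be only part of what the source reports. "The series", "measured", "known", "first", "only" and "open" are said of these compounds alone.

Measured so far in a functional assay on L1210 cells (Mus musculus) for inhibition; on this read-out lower numbers stand for stronger inhibition and higher numbers for weaker inhibition:

Compound 1 `O=c1cc(O)ccn1COCCO` — in this assay compound 1 gives > 1000 ug/mL, which is a limit of the assay and not a number.
Compound 2 `Nc1nc(Cl)c2ncn(COCCO)c2n1` — in this assay compound 2 gives 69 ug/mL.
Compound 3 `Nc1nc2c(nc(Cl)n2COCCO)c(=O)[nH]1` — in this assay compound 3 gives 350 ug/mL.

Among the two numbers shown, compound 3 stands highest; the nearest is compound 2, whose lower number lies beyond the usual scatter. The remaining value, that of compound 1, sits at the limit of > 1000 ug/mL in this assay, at which 1 of the 3 values shown sits, and is not a number.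

Compound 4 `Nc1nc2c(nc(Br)n2COCCO)c(=O)[nH]1` has not yet been measured in this assay. It differs from compound 3 in one place: bromo in place of chloro on an aromatic carbon. Going by the values given here, no step between measured compounds of this kind is available, so the size of the change can only be expected, not read off. The step of no change at the digits printed from compound 3 to compound 4 (within the scatter) is expected to be small, within the scatter, with no clear direction. Compound 4 is therefore estimated at 350 ug/mL, with a range from 150 ug/mL to 800 ug/mL.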

Compound 4, concentration for 50% inhibition: 355 ug/mL
Compound 4: middle estimate off by 1.0-fold (0.01 log units), on the low side; low and high end bracket the measured number.
By their numbers in this assay, from the lowest: compound 2; then compounds 3 and 4 (each within the scatter of the next). At a limit, above all of these: compound 1.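

In this assay, bromo in place of chloro on the aromatic carbon between two ring nitrogen atoms gives a 1.0-fold higher number from compound 3 to compound 4 (0.01 log units; within the scatter). Going by these compounds alone, this is the only step here between compounds that differ in one place, and it shows that the read-out does not separate these two halogens at this position on this core, which the earlier compounds alone could not show. Nothing measured here bears on why the two halogens read alike.

As far as these compounds go, whether an amine or a methyl group at this position would read like compound 3 and compound 4 stays open, since two halogens say little about the position as a whole. Also open, from the compounds shown here alone, is whether bromo in place of chloro on compound 2 would likewise leave the number within the scatter.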